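This account rests on a few compounds, and the source may have more. Where it says the series, first, only, none or still open, it means among the compounds named here.

In a functional assay on PC-3 cells (Homo sapiens) for antiproliferative activity, read by MTT assay, with a stated time of 24 h (a higher number here means a weaker inhibitor, a lower number a stronger inhibitor), compound 3 `CCn1c(C(=O)N[C@H](CO)C(C)C)ccc1C(CC)(CC)c1ccc(OCS(=O)(=O)c2ccccc2)c(C)c1` gives 7300 nM and lies within the scatter of both its relatives, compound 1 `CCN(CC)CCNC(=O)c1ccc(C(CC)(CC)c2ccc(OCS(=O)(=O)c3ccccc3)c(C)c2)n1CC` at 7130 nM and compound 2 `CCn1c(C(=O)N[C@@H](C)CO)ccc1C(CC)(CC)c1ccc(OCS(=O)(=O)c2ccccc2)c(C)c1` at 9520 nM on the same read-out. Compound 4 `CCn1c(C(=O)NCC(=O)O)ccc1C(CC)(CC)c1ccc(OCS(=O)(=O)c2ccccc2)c(C)c1` differs from compound 3 as follows: carboxymethyl in place of 1-(hydroxymethyl)-2-methylpropyl on an amide-type nitrogen and so, in short, carboxymethyl in place of 1-(hydroxymethyl)-2-methylpropyl on an amide-type nitrogen. Within the data shown here, three measured steps concern the group on that nitrogen: a 1.3-fold higher number from compound 1 to compound 2 (0.13 log units; within the scatter) and a 1.0-fold higher number from compound 1 to compound 3 (0.01 log units; within the scatter) and a 1.3-fold lower number from compound 2 to compound 3 (0.12 log units; within the scatter) all stay within the scatter. None of them involves carboxymethyl, so this evidence is indirect. No step beyond the scatter is therefore expected, and the estimated change is a 1.1-fold higher number from compound 3 to compound 4 (0.04 log units; within the scatter) overall. Compound 4 is expected near 8000 nM within an estimated range of 3500 nM to 20000 nM when measured.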

Compound 4, half-maximal inhibitory concentration: 30100 nM
Beside the measured number, compound 4's estimate is 3.8-fold (0.58 log units) below it; the whole stated range lies below it.
By their numbers in this assay, from the lowest: compounds 1, 3 and 2 (each within the scatter of the next); then compound 4.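

Unlike the earlier changes on the amide-type nitrogen, carboxymethyl takes the number beyond the scatter, with a 4.1-fold higher number from compound 3 to compound 4 (0.62 log units; beyond the scatter) and a 3.2-fold higher number from compound 2 to compound 4 (0.50 log units; beyond the scatter) and a 4.2-fold higher number from compound 1 to compound 4 (0.63 log units; beyond the scatter) as its three steps. This shows that the group on that nitrogen can matter, and compound 4 is the weakest of the four compounds. Nothing given here explains the shift. On these data alone, it remains open whether the shift belongs to the carboxylic acid itself or to the short chain carrying it. A methyl ester, a primary amide or a longer chain ending in a carboxylic acid on that nitrogen would separate these readings.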